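The source may report more compounds than this note shows. Statements on the series, on what has been measured and on what is new or still open speak of the compounds shown alone.

Measured in an ADME assay on HepG2 cells (Homo sapiens) for cytotoxicity, read by MTT assay, with a stated time of 72 h; on this read-out higher numbers stand for lower toxicity in this test and lower numbers for higher toxicity in this test:
- Compound 1 `O=[N+]([O-])c1c(CS(=O)(=O)c2ccccc2)nc2c(-c3ccc(Cl)cc3)cc(Cl)cn12`: > 3900 nM, a limit.
- Compound 2 `COc1ccc(-c2cc(Cl)cn3c([N+](=O)[O-])c(CS(=O)(=O)c4ccccc4)nc23)cc1`: > 3900 nM, a limit.
- Compound 3 `O=[N+]([O-])c1c(CS(=O)(=O)c2ccccc2)nc2c(-c3ccc(CO)cc3)cc(Cl)cn12`: 13100 nM.

Among the compounds with values here, compound 3 carries the only actual number of the three. The other two values are bounded by the limit of > 3900 nM in this assay, at which 2 of the 3 values shown sit.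

Compound 4 `O=[N+]([O-])c1c(CS(=O)(=O)c2ccccc2)nc2c(-c3ccccc3CO)cc(Cl)cn12` differs from compound 3 by 2-(hydroxymethyl)phenyl in place of 4-(hydroxymethyl)phenyl on an aromatic carbon, with the same atoms joined differently.

The measured steps are a step that the two limits leave unreadable from compound 1 to compound 2, a step that the limit leaves unreadable from compound 1 to compound 3 and a step that the limit leaves unreadable from compound 2 to compound 3. None has a readable size, and each exchanges one group for another, so none shows what moving the hydroxymethyl group does. Within the data shown here, the only firm anchor is compound 3 at 13100 nM.

Among the measured compounds shown here, with no measured step to support a direction, the expected 1.1-fold lower number from compound 3 to compound 4 (0.04 log units; within the scatter) in this assay stays within the usual scatter. For compound 4 the estimate is 12000 nM, with an expected range of 5000 nM to 30000 nM.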

Compound 4, half-maximal cytotoxic concentration: 88000 nM
Compound 4: the middle estimate sits 7.3-fold (0.87 log units) below what was measured; the whole stated range lies below it.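

In this assay, 2-(hydroxymethyl)phenyl in place of 4-(hydroxymethyl)phenyl on this aromatic carbon of the shared core gives a 6.7-fold higher number from compound 3 to compound 4 (0.83 log units; beyond the scatter). Within the data shown here, this is the only readable step so far, and it lies beyond the scatter. The two groups have the same atoms joined differently. The attachment pattern of the hydroxymethyl group alone is enough to shift the read-out at this position, here towards lower toxicity in this test.

The steps to compound 4 from compound 1 and compound 2 cannot be read, because the values of those two compounds are limits: the limit of > 3900 nM in this assay, at which 2 of the 4 values shown sit.
As far as these compounds go, it remains open whether an aminomethyl group or a carboxylic acid on the same phenyl ring would show the same dependence on attachment as the hydroxymethyl pair.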